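Working notes: from compound 3 to compound 4

The source may report more compounds than this note shows. Statements on the series, on what has been measured and on what is new or still open speak of the compounds shown alone.

Values in a functional assay on HepG2 cells (Homo sapiens) for antiproliferative activity, read by MTT assay, with a stated time of 72 h; a lower number here means a stronger inhibitor, a higher number a weaker inhibitor:
- compound 1 `NC1=NC2(CCSCC2)N(OCCCOc2ccc(Cl)c(Cl)c2)C(N)=N1`: 70 nM
- compound 2 `CC(C)(C)c1ccc(OCCCON2C(N)=NC(N)=NC23CCSCC3)cc1`: 70 nM
- compound 3 `NC1=NC2(CCSCC2)N(OCCCOc2cc(Cl)c(Cl)cc2Cl)C(N)=N1`: > 100000 nM

In this assay compound 3 gives only a limit, > 100000 nM. Compound 4 `NC1=NC2(CCSCC2)N(OCCCOc2ccc(Cl)cc2)C(N)=N1` arises from compound 3 by one change: 4-chlorophenyl in place of 2,4,5-trichlorophenyl on an oxygen on a saturated carbon. Among the compounds with values here, one measured step bears on this change: an at least 1400-fold higher number from compound 1 to compound 3 (3.15 log units; beyond the scatter), a large step beyond the scatter, with chloro in place of hydrogen on an aromatic carbon. Compound 4 removes chloro rather than adding it, so a large step in the opposite direction, towards a lower number, is expected. The expected step is an at least 660-fold lower number from compound 3 to compound 4 (2.82 log units; beyond the scatter). For compound 4 the estimated value is 150 nM, with an expected range of 30 nM to 2000 nM.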

Compound 4, half-maximal inhibitory concentration: 1100 nM
For compound 4 the middle estimate is 7.3-fold (0.87 log units) below the measured one; measured number inside the range.
By their numbers in this assay, from the lowest: compounds 1 and 2 (each within the scatter of the next); then compound 4. At a limit, above all of these: compound 3.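

In this assay, 4-chlorophenyl in place of 2,4,5-trichlorophenyl on the oxygen brings the series back to a measurable value, with an at least 90-fold lower number from compound 3 to compound 4 (1.95 log units; beyond the scatter); compound 3 is only a limit, so this step is a bound: the limit of > 100000 nM in this assay, at which 1 of the 4 values shown sits.
Compound 4 still trails both other compounds, with a 16-fold higher number from compound 1 to compound 4 (1.20 log units; beyond the scatter) and a 16-fold higher number from compound 2 to compound 4 (1.20 log units; beyond the scatter).
The number of chloro groups therefore gives no one-way trend: compound 1 carries more chloro than compound 4 and has the lower number, whereas compound 3 carries the most and stands at a limit.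

Open, as far as these compounds go, is whether an amine or a carboxylic acid on the aromatic ring would keep the number low. From the compounds shown here alone, the effect of a longer chain to the oxygen also remains open.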